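From 4-bromophenyl to ethyl: notes on compound 3

A few compounds are considered here, and "the series" means these few. Any claim that something is new, unique, unknown or untested is made for them only; others in the source may bear on it.

Going by the values given here, in a functional assay on RS4-11 cells (Homo sapiens) for antiproliferative activity, read by MTT assay, with a stated time of 48 h (on this read-out lower numbers stand for an effect already at smaller amounts and higher numbers for an effect only at larger amounts of compound), compound 1 `COC(=O)c1[nH]c2cc(OC)ccc2c1-c1ccc(Br)cc1` gives 200 nM, the only number available for the series. Compound 2 `COC(=O)c1[nH]c2cc(C(F)(F)F)ccc2c1-c1ccc(C(F)(F)F)cc1` reads > 100000 nM in this assay, and this is a limit of the assay, not a number. The two compounds differ in more than one place, so no single-change step can be read from them.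

Compound 3 `CCc1c(C(=O)OC)[nH]c2cc(OC)ccc12` is related to compound 1 by one change: ethyl in place of 4-bromophenyl on an aromatic carbon. The methoxycarbonyl group and the rest of the core of compound 1 stay as they are.

No measured case of a small chain at this place exists. The expectation therefore rests on compound 1, at 200 nM, which holds the aromatic ring that compound 3 gives up. Compound 2 also holds such a ring, so the ring alone does not secure a number. The expected change is a 25-fold higher number from compound 1 to compound 3 (1.40 log units; beyond the scatter), towards a higher number and beyond the scatter. Compound 3 is estimated at 5000 nM, with an expected range of 600 nM to 50000 nM.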

Compound 3, half-maximal effective concentration: > 100000 nM
Compound 3 ended at the assay's limit; the forecaster's own chance of this, stated with the estimate: 25%; middle value at least 20-fold (1.30 log units) from the limit.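

Ethyl in place of 4-bromophenyl on this aromatic carbon gives an at least 500-fold higher number from compound 1 to compound 3 (2.69 log units; beyond the scatter), the first single-change step in the series, and it shows that the activity of compound 1 in this assay does not persist when a small chain without a ring stands at this place. For compound 3, > 100000 nM is a limit of the assay and not a number. The step therefore marks only the smallest loss consistent with the data, and its full size cannot be read because the read-out ends at a limit: the limit of > 100000 nM in this assay, at which 2 of the 3 values shown sit.

The compounds shown do not separate what the aromatic ring contributes from what the bromine contributes, nor whether the loss follows from the absence of the ring or from the smaller size of the group, a question that a plain phenyl, a 4-chlorophenyl or a longer chain such as hexyl at this place would address. Compound 2 differs from compound 1 in more than one place, so it leaves open which of its trifluoromethyl groups, if either alone, goes with its limit.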